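The source may hold more compounds than are shown below. What is called first, only, known or untested is meant among the compounds shown, and "the series" means these compounds.

Compound 1 `Clc1cccc(-c2cc(-c3ccc(Cl)o3)cc(-c3cccs3)n2)c1` sets the reference point. In a functional assay on HCT-15 cells (Homo sapiens) for cytotoxicity, in the presence of a further agent that is not named here (on this read-out higher numbers stand for weaker inhibition and lower numbers for stronger inhibition), compound 1 gives 15500 nM, the top end of the three numbers in hand, although its separation from compound 2 `Clc1cccc(-c2cc(-c3ccc(Cl)o3)cc(-c3ccsc3)n2)c1`, which gives 13700 nM, lies within the scatter; only compound 3 `Cc1ccc(-c2cc(-c3ccc(Cl)o3)cc(-c3ccsc3)n2)cc1`, with 7410 nM, stands clearly below it.

The step to compound 4 `Clc1ccc(-c2cc(-c3ccco3)nc(-c3cccs3)c2)o1` alters compound 1 in one place: furan-2-yl in place of 3-chlorophenyl on an aromatic carbon. The group that leaves is the same 3-chlorophenyl that was exchanged on the way from compound 2 to compound 3, where the replacement by 4-methylphenyl gave a 1.8-fold lower number from compound 2 to compound 3 (0.27 log units; within the scatter). The other measured step, an exchange of the thiophene attachment, gave a 1.1-fold lower number from compound 1 to compound 2 (0.05 log units; within the scatter). Within the data shown here, both moves at these outer aryl positions stayed within the scatter, so a third exchange at the same position of the shared core is expected to do the same: no step in this assay beyond the scatter, with at most a mild drift downward.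

Compound 4 is therefore estimated at 12000 nM, within a range of 5000 nM to 30000 nM, which means an expected step of a 1.3-fold lower number from compound 1 to compound 4 (0.11 log units; within the scatter).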

Compound 4, half-maximal inhibitory concentration: > 50000 nM
Compound 4 ended at the assay's limit; the forecaster's own chance of this, stated with the estimate: 10%; middle value at least 4.1-fold (0.61 log units) from the limit.
By their numbers in this assay, from the lowest: compounds 3, 2 and 1 (each within the scatter of the next, the first and the last beyond it). At a limit, above all of these: compound 4.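

Compound 4 stands at > 50000 nM, which is a limit of this assay and not a number. Among these compounds, the position next to the ring nitrogen, which had so far looked undemanding, is therefore not indifferent to what it carries: with an at least 3.2-fold higher number from compound 1 to compound 4 (0.50 log units; beyond the scatter), furan-2-yl in place of 3-chlorophenyl moves beyond the scatter and towards weaker inhibition, whereas 4-methylphenyl in place of the same group, on the thiophen-3-yl compound, gave a 1.8-fold lower number from compound 2 to compound 3 (0.27 log units; within the scatter), which stays within it. As far as these compounds go, how much inhibition is lost with furan-2-yl remains unknown, and the step gives only a minimum, because compound 4 sits at a limit: the limit of > 50000 nM in this assay, at which 1 of the 4 values shown sits.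

Furan-2-yl differs from 3-chlorophenyl in ring size, in its ring oxygen and in the absence of chlorine all at once, so the compounds shown do not tell which of these goes with the change; unsubstituted phenyl or thiophen-2-yl at this position would begin to separate them. Also open, from the compounds shown here alone, is whether furan-2-yl behaves the same way alongside thiophen-3-yl, and how a pyridinyl group or an aminophenyl group would fare at this position.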